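This account rests on a few compounds, and the source may have more. Where it says the series, first, only, none or still open, it means among the compounds named here.

Measured in a functional assay on PC-9 cells (Homo sapiens) for inhibition, read by MTT assay, with a stated time of 72 h; a higher number here means a weaker inhibitor, a lower number a stronger inhibitor:
- Compound 1 `Cc1cc(Nc2ccn(Cc3ccccc3)n2)n2nc(SCc3ccc(Br)cc3)nc2n1`: > 50000 nM
- Compound 2 `Cc1cc(Nc2cc(-c3ccccc3)[nH]n2)n2nc(SCc3ccccc3Br)nc2n1`: 5630 nM
- Compound 3 `Cc1cc(Nc2cc(C(C)(C)C)[nH]n2)n2nc(SCc3ccc(Br)cc3)nc2n1`: 12400 nM

The entry for compound 1 is a limit of the assay and not a number. Compound 2 holds the lower of the two numbers, and compound 3 stands beyond the scatter from it. Compound 4 `Cc1cc(Nc2cc(-c3ccccc3)[nH]n2)n2nc(SCc3cccc4ccccc34)nc2n1` carries naphthalen-1-yl in place of 2-bromophenyl on a saturated chain carbon bound to a sulfur. Going by the values given here, no measured pair isolates this change, so the expectation rests on compound 2 at 5630 nM alone. In this assay the expected change is a 1.1-fold lower number from compound 2 to compound 4 (0.05 log units; within the scatter), which is none beyond the scatter. For compound 4 the estimated value is 5000 nM, with an expected range from 1500 nM to 20000 nM.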

Compound 4, half-maximal inhibitory concentration: 3950 nM
Compound 4: middle estimate off by 1.3-fold (0.10 log units), on the high side; measured number inside the range.
By their numbers in this assay, from the lowest: compounds 4 and 2 (each within the scatter of the next); then compound 3. At a limit, above all of these: compound 1.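

Putting naphthalen-1-yl in place of 2-bromophenyl on a saturated chain carbon bound to a sulfur gives a 1.4-fold lower number from compound 2 to compound 4 (0.15 log units; within the scatter) in this assay. This first single-place comparison shows that, at this position, a second six-membered aromatic ring together with the loss of bromine cannot be told apart from 2-bromophenyl. Nothing measured here bears on why the two groups read alike. The compounds shown leave open whether a non-aromatic group here, such as cyclohexyl or a chain ending in an amine, would read the same.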